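The source may report more compounds than this note shows. Statements on the series, on what has been measured and on what is new or still open speak of the compounds shown alone.

Measured in a functional assay with Homo sapiens as the target; on this read-out lower numbers stand for stronger inhibition and higher numbers for weaker inhibition:

- Compound 1 `CC(C)[C@H](NC(=O)COc1cccc2ccccc12)C(=O)N[C@@H](CC(=O)O)C(=O)COc1cccc(C(F)(F)F)c1`: 16600 nM
- Compound 2 `CC(C)[C@H](NC(=O)COc1cccc2ccccc12)C(=O)N[C@@H](CC(=O)O)C(=O)COc1ccccc1F`: 15700 nM
- Compound 3 `CC(C)[C@H](NC(=O)COc1cccc2ccccc12)C(=O)N[C@@H](CC(=O)O)C(=O)COc1cccc(F)c1`: 12000 nM

Compound 3 lies within the usual scatter of both other compounds, so these three values cannot be ranked. Compound 4 `CC(C)[C@H](NC(=O)COc1cccc2ccccc12)C(=O)N[C@@H](CC(=O)O)C(=O)COc1c(F)cccc1F` is not yet measured. It differs from compound 3 by one change, 2,6-difluorophenyl in place of 3-fluorophenyl on an oxygen on a saturated carbon.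

Among the measured compounds shown here, three measured steps concern this same group. Putting 3-fluorophenyl in place of 2-fluorophenyl gave a 1.3-fold lower number from compound 2 to compound 3 (0.12 log units; within the scatter). Putting fluoro in place of trifluoromethyl gave a 1.4-fold lower number from compound 1 to compound 3 (0.14 log units; within the scatter). Putting 2-fluorophenyl in place of 3-(trifluoromethyl)phenyl gave a 1.1-fold lower number from compound 1 to compound 2 (0.02 log units; within the scatter). All three are within the scatter. For the measured compounds named here, no measured compound carries the 2,6-difluorophenyl group, so this remains an extrapolation.

No step beyond the scatter is therefore expected in this assay, and the expected step is a 1.2-fold higher number from compound 3 to compound 4 (0.07 log units; within the scatter). The estimate for compound 4 is 14000 nM, with an expected range from 7000 nM to 28000 nM.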

Compound 4, half-maximal inhibitory concentration: > 100000 nM
Compound 4 ended at the assay's limit; the forecaster's own chance of this, stated with the estimate: 10%; at least 7.1-fold (0.85 log units) between middle value and limit.
By their numbers in this assay, from the lowest: compounds 3, 2 and 1 (each within the scatter of the next). At a limit, above all of these: compound 4.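

In this assay compound 4 gives > 100000 nM, which is a limit of the assay and not a number: the limit of > 100000 nM in this assay, at which 1 of the 4 values shown sits. The earlier compounds shown here could not be told apart, but they hid how much this position on the oxygen can respond to a change of ring, and all three new steps lie beyond the scatter: an at least 8.3-fold higher number from compound 3 to compound 4 (0.92 log units; beyond the scatter), an at least 6.3-fold higher number from compound 2 to compound 4 (0.80 log units; beyond the scatter), and an at least 6.0-fold higher number from compound 1 to compound 4 (0.77 log units; beyond the scatter). Adding a fluoro to the 2-fluorophenyl group of compound 2 thus has a clear effect here, unlike the exchanges among the three earlier groups.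

Going by these compounds, the full size of these steps stays open, since compound 4 sits at a limit. Also open, on these data alone, is whether a 2,6-dichlorophenyl or 2,6-dimethylphenyl group would end at the same limit, and where a plain phenyl group would fall.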